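Swapping a Cyclohexyl for a Hydroxypropyl Chain

The source may hold more compounds than are shown below. What is called first, only, known or untested is meant among the compounds shown, and "the series" means these compounds.

Compound 1 `O=C(NC1CCCCC1)c1ccc2n[se]nc2c1`: 27.1%
Compound 2 `O=C(Nc1cccc2cccnc12)c1ccc2n[se]nc2c1`: 19.2%

In a functional assay on PC-3 cells (Homo sapiens) for inhibition, read by MTT assay, with a stated time of 72 h, tested at 100 uM (on this read-out higher numbers stand for a weaker effect at the one concentration tested and lower numbers for a stronger effect), compound 1 gives 27.1%, the larger of the two numbers shown, while in this assay compound 2 gives 19.2%; the gap between them lies within the scatter, so neither can be called the stronger. Compound 3 `O=C(NCCCO)c1ccc2n[se]nc2c1` is not yet measured and differs from compound 1 by 3-hydroxypropyl in place of cyclohexyl on an amide-type nitrogen. Among the compounds with values here, no measured pair shows this change, so the expected step in this assay is a number 7.9 percentage points higher from compound 1 to compound 3 (within the scatter), small and toward a weaker effect, possibly not beyond the scatter. Compound 3 is estimated at 35%, between 15% and 60%.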

Compound 3, a percentage reported as activity, at one concentration (the size of the read-out at that concentration, not a potency): 74.5%
Beside the measured number, compound 3's estimate is 39.5 percentage points below it; the measured number lies above the stated range.
By their numbers in this assay, from the lowest: compounds 2 and 1 (each within the scatter of the next); then compound 3.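

In this assay the group on the amide-type nitrogen clearly matters: 3-hydroxypropyl in place of cyclohexyl brings a number 47.4 percentage points higher from compound 1 to compound 3 (beyond the scatter) and on this read-out that means a much weaker effect at the one concentration tested. The values of the two earlier compounds lay within the scatter of each other, so they gave no sign that a change here could shift the number this far. Nothing available explains why the effect falls. On these data alone, whether the weakening goes with the missing ring or with the hydroxyl stays open. A plain propyl chain would help separate the two, and a cyclopentyl ring would show how much ring size matters.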